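This account rests on a few compounds, and the source may have more. Where it says the series, first, only, none or still open, it means among the compounds named here.

Of the compounds shown here, three have so far been measured in a functional assay on Huh-5-2 cells (Homo sapiens) for cytotoxicity, read by microscopy; a higher number here means that more compound is tolerated, a lower number that less compound is tolerated. Compound 1 `CC(=O)OC[C@H]1O[C@@H](n2c(SCc3cc4cc(Br)ccc4oc3=O)nc3cncnc32)[C@H](O)[C@@H]1O` gives 31000 nM in this assay. Compound 2 `CC(=O)OC[C@H]1O[C@@H](n2c(SCc3cc4cc(Br)cc(Br)c4oc3=O)nc3cncnc32)[C@H](O)[C@@H]1O` carries the change bromo in place of hydrogen on an aromatic carbon on the same core; in this assay compound 2 gives 7000 nM, and the step is a 4.4-fold lower number from compound 1 to compound 2 (0.65 log units; beyond the scatter). Compound 3 `CC1(C)O[C@@H]2[C@H](O1)[C@H](n1c(SCc3cc4ccccc4oc3=O)nc3cncnc31)O[C@@H]2CO` rests on a different core; the difference between the two cores is not broken down here. In this assay compound 3 gives 8800 nM, the second highest of the three numbers, within the scatter of compound 2 and beyond it relative to compound 1.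

Compound 4 `CC1(C)O[C@@H]2[C@H](O1)[C@H](n1c(SCc3cc4cc(Br)ccc4oc3=O)nc3cncnc31)O[C@@H]2CO` has not yet been measured. It differs from compound 3 by bromo in place of hydrogen on an aromatic carbon, the same kind of change as that from compound 1 to compound 2, but not the same: in compound 2 the entering bromo is ortho to a fused ring, meta to a bromo group and meta to a fused ring, whereas in compound 4 it is meta to a fused ring and para to a fused ring. The expectation for compound 4 rests on one precedent only, the step of a 4.4-fold lower number from compound 1 to compound 2 (0.65 log units; beyond the scatter). With the bromo at a different place, a smaller step is expected, a 2.0-fold lower number from compound 3 to compound 4 (0.30 log units; within the scatter). Compound 4 is therefore expected to give about 4400 nM in this assay, within a range from 1500 nM to 12000 nM.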

Compound 4, half-maximal cytotoxic concentration: 7500 nM
Compound 4: middle estimate off by 1.7-fold (0.23 log units), on the low side; the measured number falls inside the stated range.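

In this assay, bromo in place of hydrogen on an aromatic carbon does not carry over from one core to another as a single fixed step: the same change on two cores in this assay, a 4.4-fold lower number (0.65 log units; beyond the scatter) from compound 1 to compound 2 and a 1.2-fold lower number (0.07 log units; within the scatter) from compound 3 to compound 4, 3.8-fold (0.58 log units) apart, beyond the scatter of two such steps

On the core of compound 3, the step reads a 1.2-fold lower number from compound 3 to compound 4 (0.07 log units; within the scatter) and so gives no change that can be told from the scatter for a bromo meta to a fused ring and para to a fused ring. This does not show that the core alone separates the two steps: the entering bromo stands at a different place in each, and compound 1 already carries a bromo where compound 3 carries only hydrogen, so core, place and the bromo already present remain tangled.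

Still open, on these data alone, is whether a bromo entering at the same place on both cores would give matching steps. Also open, as far as these compounds go, is how another group at this place, such as chloro, an amine or a carboxylic acid, would read on either core.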